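This account rests on a few compounds, and the source may have more. Where it says the series, first, only, none or still open, it means among the compounds named here.

The series shares one core, carried by compound 1 `CC(C)Oc1ccccc1OC(C)C1=NCCN1`, compound 2 `Cc1cccc(C)c1OC(C)C1=NCCN1` and compound 3 `CC(Oc1ccccc1Br)C1=NCCN1`, which differ only in what is attached to the aromatic ring. In an assay on CHO cells for displacement of a labelled ligand from Alpha-2C adrenergic receptor (Homo sapiens) (a higher number here means a weaker inhibitor, a lower number a stronger inhibitor), compound 1 gives 398 nM, compound 2 gives 251 nM and compound 3 gives 282 nM. Compound 3 has the second highest of the three numbers; its closest neighbour is compound 2 and its most distant is compound 1, and all of these gaps fall within the scatter. For the measured compounds named here, the one single-point step that has been measured is a 1.4-fold lower number from compound 1 to compound 3 (0.15 log units; within the scatter).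

Compound 4 `CC(Oc1ccccc1S(C)(=O)=O)C1=NCCN1` is not yet measured. It differs from compound 3 as follows: methylsulfonyl in place of bromo on an aromatic carbon. Going by the values given here, no measured step involves methylsulfonyl, so the only guidance is indirect: the one change at this position, from isopropoxy to bromo, left this assay unmoved beyond the scatter, which suggests the position tolerates some variation, but a group of four heavy atoms with two hydrogen-bond acceptors is a different kind of change from anything tested. Compound 4 is therefore expected to show a 2.0-fold higher number from compound 3 to compound 4 (0.30 log units; within the scatter), a step that may or may not exceed the scatter. The estimate for compound 4 is 560 nM, with a range from 160 nM to 2000 nM.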

Compound 4, inhibition constant: 3800 nM
For compound 4 the middle estimate is 6.8-fold (0.83 log units) below the measured one; measured number above the stated range.
By their numbers in this assay, from the lowest: compounds 2, 3 and 1 (each within the scatter of the next); then compound 4.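

The position looked undemanding while only isopropoxy and bromo had been compared, but in this assay that tolerance does not extend to methylsulfonyl, which gives a 13-fold higher number from compound 3 to compound 4 (1.13 log units; beyond the scatter) and, measured against isopropoxy, a 9.5-fold higher number from compound 1 to compound 4 (0.98 log units; beyond the scatter). Both steps lie beyond the scatter, so this position on the aromatic ring can respond strongly to what it carries, even though the exchange of isopropoxy for bromo did not move the number beyond the scatter. The change swaps one heavy atom and no hydrogen-bond acceptors for four heavy atoms and two hydrogen-bond acceptors, and no available evidence shows which feature of methylsulfonyl accounts for the higher number.

The compounds shown leave open whether a sulfonamide, a nitrile or a methylthio group at this position would stay close to bromo and isopropoxy or rise as methylsulfonyl does. They also leave open whether methylsulfonyl would bring a step of similar size on a ring that also carries a methyl group, as the ring of compound 2 does.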